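This account rests on a few compounds, and the source may have more. Where it says the series, first, only, none or still open, it means among the compounds named here.

In a functional assay on CWR22R cells (Homo sapiens) for antiproliferative activity, with a stated time of 96 h (on this read-out higher numbers stand for weaker inhibition and lower numbers for stronger inhibition), compound 1 `Cc1cc(=O)oc2cc(OCC(=O)c3ccc(F)cc3)ccc12` gives > 100000 nM, which is a limit of the assay and not a number. Compound 2 `O=C(COc1ccc2c(C(F)(F)F)cc(=O)oc2c1)c1ccccc1` is reported as "not active" (no number reported), so it has no single number, and the evidence comes down to the limit of > 100000 nM in this assay, at which 1 of the 2 values shown sits. Compound 3 `O=C(COc1ccc2c(C(F)(F)F)cc(=O)oc2c1)c1ccc(F)cc1` has not been measured yet. It differs from compound 2 by fluoro in place of hydrogen on an aromatic carbon, which turns phenyl into 4-fluorophenyl. With compound 1, which already carries 4-fluorophenyl, at the limit > 100000 nM, no step beyond the scatter is expected in this assay. Compound 3 is expected near 100000 nM, with an estimated range from 50000 nM to 200000 nM.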

Compound 3, half-maximal inhibitory concentration: "not active" (no number reported)
For compound 3 the study gives words and no number; the estimate stays without a comparison.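

Compound 2 and compound 3 are both reported as not active, without a number, so no step can be read between them. In this assay the compounds shown leave open what changing phenyl to 4-fluorophenyl does.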